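This account rests on a few compounds, and the source may have more. Where it says the series, first, only, none or still open, it means among the compounds named here.

Measured compounds:

Compound 1, `COc1ccc(-c2cc3ccccc3nc2/C=C/C(=O)c2ccc([N+](=O)[O-])cc2)cc1`: 6470 nM
Compound 2, `COc1ccc(-c2cc3ccccc3nc2/C=C/C(=O)c2ccco2)cc1`: 6430 nM

Both compounds share the same core and differ only in the aromatic ring attached to the carbonyl carbon. In a functional assay on NCI-H460 cells (Homo sapiens) for antiproliferative activity, read by XTT assay, with a stated time of 72 h (on this read-out higher numbers stand for weaker inhibition and lower numbers for stronger inhibition), compound 2 gives 6430 nM, and compound 1 gives 6470 nM; the two numbers lie within the scatter of each other, so compound 2 cannot be set apart from compound 1 on this read-out.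

Compound 3, `COc1ccc(-c2cc3ccccc3nc2/C=C/C(=O)c2ccccn2)cc1`, is not yet measured. It differs from compound 2 in one place: pyridin-2-yl in place of furan-2-yl on a carbonyl carbon. Going by the values given here, the only measured step bears on the same position, exchanging one aromatic ring for another on that carbonyl carbon, and it read a 1.0-fold lower number from compound 1 to compound 2 (0.00 log units; within the scatter), no change beyond the scatter. On that single comparison, the ring exchange to compound 3 is likewise expected to bring no step beyond the scatter, a 1.0-fold lower number from compound 2 to compound 3 (0.00 log units; within the scatter). Compound 3 is therefore estimated at 6400 nM, with a range from 2500 nM to 16000 nM.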

Compound 3, half-maximal inhibitory concentration: 6260 nM
Estimate against measurement, compound 3: 1.0-fold (0.01 log units) above, within the range that was stated.
By their numbers in this assay, from the lowest: compounds 3, 2 and 1 (each within the scatter of the next).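

In this assay, pyridin-2-yl in place of furan-2-yl gives a 1.0-fold lower number from compound 2 to compound 3 (0.01 log units; within the scatter), and pyridin-2-yl in place of 4-nitrophenyl gives a 1.0-fold lower number from compound 1 to compound 3 (0.01 log units; within the scatter). With a third ring now at this place on the carbonyl carbon, neither a six-membered ring in place of a five-membered one nor a ring nitrogen in place of a ring oxygen separates the numbers of these three compounds. No measurement is available here to explain this lack of separation.

All three groups shown are aromatic rings, so it remains open whether a non-aromatic group on the carbonyl carbon, such as an amine, a carboxylic acid or a short alkyl chain, would read the same. As far as these compounds go, whether changes elsewhere on the shared core would move the number also remains open.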